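Swapping a naphthalene for a trifluoromethylphenyl on thiazole ethers

The source may report more compounds than this note shows. Statements on the series, on what has been measured and on what is new or still open speak of the compounds shown alone.

Measured compounds and their values:
Compound 1, `C=C(C)C(=O)c1ccc(OCc2nc(-c3ccc4ccccc4c3)cs2)c(C)c1C`: 2300 nM
Compound 2, `C=C(C)C(=O)c1ccc(OCc2nc(-c3ccc(C(F)(F)F)cc3)cs2)c(C)c1C`: 3100 nM
Compound 3, `C=C(CC)C(=O)c1ccc(OCc2nc(-c3ccc4ccccc4c3)cs2)c(Cl)c1Cl`: 3600 nM

All three compounds were tested in a functional assay on HL-60 cells (Homo sapiens) for inhibition, read by trypan blue exclusion, with a stated time of 72 h; on this read-out higher numbers stand for weaker inhibition of growth and lower numbers for stronger inhibition of growth. Compound 1 gives 2300 nM, and compound 2 gives 3100 nM. The two share one core and differ in one place: 4-(trifluoromethyl)phenyl in place of naphthalen-2-yl on an aromatic carbon. That change made a step of a 1.3-fold higher number from compound 1 to compound 2 (0.13 log units; within the scatter), so the two values cannot be told apart on this read-out.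

Compound 3 sits on a different core, and in this assay compound 3 gives 3600 nM. The difference between the core of compound 1 and the core of compound 3 is not broken down here. Against compound 1 and compound 2, compound 3 lies within the scatter of both, so no order among the three can be claimed.

Compound 4, `C=C(CC)C(=O)c1ccc(OCc2nc(-c3ccc(C(F)(F)F)cc3)cs2)c(Cl)c1Cl`, has not yet been measured. It relates to compound 3 as compound 2 relates to compound 1: 4-(trifluoromethyl)phenyl in place of naphthalen-2-yl on an aromatic carbon. The surroundings of the change read the same in both pairs, so it is the same change on a different core. Because the earlier step was a 1.3-fold higher number from compound 1 to compound 2 (0.13 log units; within the scatter), a step of about a 1.3-fold higher number from compound 3 to compound 4 (0.12 log units; within the scatter) is expected for compound 4. On that basis compound 4 is estimated at 4700 nM, most likely between 2000 nM and 11000 nM.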

Compound 4, concentration for 50% growth inhibition: 1600 nM
Compound 4: middle estimate off by 2.9-fold (0.47 log units), on the high side; measured number outside the range, below it.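

On the core of compound 3, the same swap of naphthalen-2-yl for 4-(trifluoromethyl)phenyl gave a 2.3-fold lower number from compound 3 to compound 4 (0.35 log units; beyond the scatter) in this assay, a modest step towards stronger inhibition of growth. Among the compounds shown here, a step measured on one core therefore did not predict the step on the other core in this small set, and the two steps differ by more than ordinary repeat-to-repeat variation: the same change on two cores in this assay, a 1.3-fold higher number (0.13 log units; within the scatter) from compound 1 to compound 2 and a 2.3-fold lower number (0.35 log units; beyond the scatter) from compound 3 to compound 4, 3.0-fold (0.48 log units) apart, beyond the scatter of two such steps This shows that the effect of the swap depends on its surroundings here, but it does not show which difference between the cores is responsible, and with only one pair on each core it says nothing about how the swap would behave on a third core.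

The compounds shown leave open whether the chlorine atoms of compound 3, its longer chain at the ketone, or the two together set the step apart, and a compound combining those chlorine atoms with the shorter chain of compound 1 would help to separate them. They also leave open how an amine or a carboxylic acid on the same aromatic carbon would behave on either core.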